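Shifting the amino substituent across a sulfamate series

The compounds below may be only part of what the source reports. "The series", "measured", "known", "first", "only" and "open" are said of these compounds alone.

In an assay on HEK293 cells for inhibition of Steryl-sulfatase (Homo sapiens), tested at 0.1 uM (on this read-out lower numbers stand for a weaker effect and higher numbers for a stronger effect at the one concentration tested), compound 2 `CCCN(Cc1ccccc1)c1cccc(C(=O)N2CCc3ccc(OS(N)(=O)=O)cc3C2)c1` gives 23.1%. Compound 1 `CN(CCCN1CCCCC1)c1cccc(C(=O)N2CCc3ccc(OS(N)(=O)=O)cc3C2)c1` carries methyl(3-(piperidin-1-yl)propyl)amino in place of benzyl(propyl)amino on an aromatic carbon, and in this assay compound 1 gives 24.1%, so that a number 1 percentage points higher from compound 2 to compound 1 (within the scatter). Compound 3 `CCCN(Cc1ccccc1)c1ccc(C(=O)N2CCc3ccc(OS(N)(=O)=O)cc3C2)cc1` is built from the same atoms as compound 2, joined differently; the difference between the two cores is not broken down here. In this assay compound 3 gives 64.8%, the highest of the three numbers. Compound 4 `CN(CCCN1CCCCC1)c1ccc(C(=O)N2CCc3ccc(OS(N)(=O)=O)cc3C2)cc1` has not yet been measured; it carries methyl(3-(piperidin-1-yl)propyl)amino in place of benzyl(propyl)amino on an aromatic carbon, the same kind of change as from compound 2 to compound 1, but here the place is para to a large group rather than meta to a large group. Because a number 1 percentage points higher from compound 2 to compound 1 (within the scatter) lay within the scatter, only a small step is expected, a number 4.8 percentage points lower from compound 3 to compound 4 (within the scatter). Compound 4 is therefore estimated at 60%, within a range from 42% to 78%.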

Compound 4, a percentage reported as inhibition, at one concentration (the size of the read-out at that concentration, not a potency) in the Steryl-sulfatase assay: 17.4%
Compound 4: middle estimate off by 42.6 percentage points, on the high side; measured number below the stated range.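

In the Steryl-sulfatase assay compound 3 gives 64.8% and compound 4 gives 17.4%. In the Steryl-sulfatase assay, methyl(3-(piperidin-1-yl)propyl)amino in place of benzyl(propyl)amino gives a number 47.4 percentage points lower from compound 3 to compound 4 (beyond the scatter). The step therefore depends on the core and cannot be carried from one core to the other in this series: the same change on two cores in the Steryl-sulfatase assay, a number 1 percentage points higher (within the scatter) from compound 2 to compound 1 and a number 47.4 percentage points lower (beyond the scatter) from compound 3 to compound 4, 48.4 percentage points apart, beyond the scatter of two such steps. In a physicochemical assay for lipophilicity (on this read-out lower numbers stand for lower lipophilicity and higher numbers for higher lipophilicity), compound 3 gives 1.93 and compound 4 gives 1.93. In the physicochemical assay the same change shows no change at the digits printed from compound 3 to compound 4 (within the scatter), and these data do not show what in the two cores sets the steps apart, or whether the difference extends beyond these four compounds.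

The compounds shown leave open which part of the substituent matters on the core of compound 3, as the whole group changes at once. Also open, on these data alone, is how a morpholine in place of the piperidine ring, or a simple dimethylamino group, would behave on either core.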